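Working notes: moving the trifluoromethyl around the shared core

This account rests on a few compounds, and the source may have more. Where it says the series, first, only, none or still open, it means among the compounds named here.

Compound 3 `Oc1ccccc1-c1cc(-c2ccccc2C(F)(F)F)cc(-c2ccccc2O)n1` gives 5800 nM in a functional assay on HeLa cells (Homo sapiens) for inhibition (on this read-out lower numbers stand for stronger inhibition and higher numbers for weaker inhibition), and stands lowest of the two numbers recorded. Compound 2 `Oc1ccc(-c2cc(-c3ccc(F)cc3)cc(-c3ccc(O)cc3)n2)cc1` gives 8680 nM in this assay, within the scatter of compound 3. Compound 1 `Oc1ccccc1-c1cc(-c2ccc(F)cc2)cc(-c2ccccc2O)n1` gives only a limit of this assay, > 50000 nM, and no number. For the measured compounds named here, the single measured step in one place is an at least 8.6-fold lower number from compound 1 to compound 3 (0.93 log units; beyond the scatter); its size is open-ended because it rests on (the limit of > 50000 nM in this assay, at which 1 of the 3 values shown sits).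

Compound 4 `Oc1ccccc1-c1cc(-c2ccc(C(F)(F)F)cc2)cc(-c2ccccc2O)n1` differs from compound 3 by 4-(trifluoromethyl)phenyl in place of 2-(trifluoromethyl)phenyl on an aromatic carbon. Going by the values given here, no measured step matches this change directly. The measured step bears on it only in part: it exchanged 4-fluorophenyl for 2-(trifluoromethyl)phenyl and lowered the number beyond the scatter. Compound 4 carries its trifluoromethyl in the 4-(trifluoromethyl)phenyl arrangement, as compound 1 carries its fluorine in 4-fluorophenyl, and compound 1 sits at the limit. That is weak evidence, since it confounds the change of group with the change of position. A step of a 2.6-fold higher number from compound 3 to compound 4 (0.41 log units; beyond the scatter) towards a higher number is expected for compound 4, with considerable spread. Compound 4 is estimated at 15000 nM in this assay, between 4000 nM and 60000 nM, and a limit rather than a number is a real possibility.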

Compound 4, half-maximal inhibitory concentration: > 50000 nM
Compound 4 gave a limit, no number; the forecaster's own chance of this, stated with the estimate: 30%; middle value at least 3.3-fold (0.52 log units) away from the limit.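

This step changes position alone: the group keeps the same atoms and stays on the aromatic carbon opposite the ring nitrogen, yet 4-(trifluoromethyl)phenyl in place of 2-(trifluoromethyl)phenyl gives an at least 8.6-fold higher number from compound 3 to compound 4 (0.93 log units; beyond the scatter). The earlier step from 4-fluorophenyl to 2-(trifluoromethyl)phenyl changed the group and its position together, whereas this pair shows that, in this assay, the place of the trifluoromethyl on this phenyl ring matters on its own, and that trifluoromethyl as such does not carry the lower number of compound 3. The size of this step is open-ended, and the steps between compound 1 and compound 4 cannot be read, because they rest on a limit and not a number: the limit of > 50000 nM in this assay, at which 2 of the 4 values shown sit.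

Going by these compounds, it remains open whether the lower number of compound 3 is specific to trifluoromethyl, or whether another group at the same place on the phenyl ring, such as an amine, a carboxylic acid or a longer chain, would keep it. On these data alone, it is also open whether the same change of position would have a similar effect with the 4-hydroxyphenyl groups of compound 2 on the shared core.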